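Fluoro for hydroxy on the one measurable compound

This account rests on a few compounds, and the source may have more. Where it says the series, first, only, none or still open, it means among the compounds named here.

Among the compounds with values here, in a functional assay on MGC-803 cells (Homo sapiens) for antiproliferative activity, read by MTT assay, with a stated time of 72 h (a higher number here means a weaker inhibitor, a lower number a stronger inhibitor), compound 3 `C/C(=N\NC(=O)c1cccc(S(=O)(=O)N2CCOCC2)c1)c1cc(O)ccc1O` gives 9090 nM as the only actual number in this small set. Compound 1 `C/C(=N\NC(=O)c1cccc(S(=O)(=O)N2CCOCC2)c1)c1ccc(F)cc1` sits at a limit (> 100000 nM). Compound 2 `C/C(=N\NC(=O)c1cccc(S(=O)(=O)N2CCOCC2)c1)c1cccc(O)c1` also sits at a limit (> 100000 nM).

Compound 4 `C/C(=N\NC(=O)c1cccc(S(=O)(=O)N2CCOCC2)c1)c1cc(F)ccc1O` differs from compound 3 by fluoro in place of hydroxy on an aromatic carbon, turning 2,5-dihydroxyphenyl into 5-fluoro-2-hydroxyphenyl. Within the data shown here, two measured steps bear on this change. One is an at least 11-fold lower number from compound 1 to compound 3 (1.04 log units; beyond the scatter) for 2,5-dihydroxyphenyl in place of 4-fluorophenyl. The other is an at least 11-fold lower number from compound 2 to compound 3 (1.04 log units; beyond the scatter) for hydroxy in place of hydrogen on an aromatic carbon. On these data alone, both are large, though each starts from a limit, so their true sizes remain open.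

Among the measured compounds shown here, compound 4 keeps the 2-hydroxy group, the hydroxy gained in an at least 11-fold lower number from compound 2 to compound 3 (1.04 log units; beyond the scatter) and the one that brought a number into range. It gives up only the other hydroxy, which compound 2 already carried without a readable value. No large loss is therefore expected, and the expected change in this assay is a 1.3-fold lower number from compound 3 to compound 4 (0.11 log units; within the scatter) with no firm direction. A return to the limit cannot be excluded. For compound 4 the estimated value is 7000 nM (expected range 1500 nM to 35000 nM).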

Compound 4, half-maximal inhibitory concentration: 2260 nM
The estimate for compound 4 lay 3.1-fold (0.49 log units) above the measured number, and the stated range covers the measured number.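

In this assay, within the data shown here, the hydroxy para to a hydroxy group proves replaceable, and fluoro gives the better result at this place: the change reads as a 4.0-fold lower number from compound 3 to compound 4 (0.60 log units; beyond the scatter) and so goes further than the earlier compounds could show. Set against the two compounds without a measurable number, the 5-fluoro-2-hydroxyphenyl group gives an at least 44-fold lower number from compound 2 to compound 4 (1.64 log units; beyond the scatter) as one step and an at least 44-fold lower number from compound 1 to compound 4 (1.64 log units; beyond the scatter) as the other, so a fluoro and a hydroxy together on this ring give a readable value where 3-hydroxyphenyl and 4-fluorophenyl gave none. Both steps start from a limit and so fix only a minimum size, while the step between compound 1 and compound 2 cannot be read at all: the limit of > 100000 nM in this assay, at which 2 of the 4 values shown sit.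

On these data alone, whether the gain is particular to fluoro stays open, since chloro, methyl or methoxy at the same place would be needed to tell. Also open, as far as these compounds go, is whether the hydroxy kept in compound 4 could give way to an amine, and how a carboxylic acid elsewhere on the shared core would read.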